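This account rests on a few compounds, and the source may have more. Where it says the series, first, only, none or still open, it means among the compounds named here.

Compound 3, `Cc1ccc(-c2nc3ccccc3s2)cc1NC(=O)c1cnccc1Cl`, was tested in an ADME assay on Raji cells (Homo sapiens) for inhibition, with a stated time of 72 h; a higher number here means that more compound is needed for the effect, a lower number that less compound is needed. In this assay compound 3 gives > 25000 nM, which is a limit of the assay and not a number. Two related compounds stand at the same place. Compound 1, `CC(Cl)C(=O)Nc1cccc(-c2nc3ccccc3s2)c1`, gives in this assay > 25000 nM, again a limit. Compound 2, `O=C(Nc1cccc(-c2nc3ccccc3s2)c1)c1cccnc1Cl`, gives in this assay > 25000 nM, also a limit. The step that the two limits leave unreadable from compound 1 to compound 2 therefore cannot be read, since both of its ends sit at the limit of > 25000 nM in this assay, at which 3 of the 3 values shown sit. Compound 4, `O=C(Nc1cc(-c2nc3ccccc3s2)ccc1F)c1cnccc1Cl`, differs from compound 3 by fluoro in place of methyl on an aromatic carbon. Among the measured compounds shown here, no measured step with a readable size bears on this change; the only measured step, a step that the two limits leave unreadable from compound 1 to compound 2, is unreadable. Because every value shown sits at the limit of > 25000 nM in this assay, at which 3 of the 3 values shown sit, the expectation for this assay is that compound 4 also gives no number but a limit, so no step beyond the scatter can be counted on. The step that the limit leaves unreadable from compound 3 to compound 4 that this estimate means is expected to be essentially none. Compound 4 is estimated at 40000 nM, with a range from 15000 nM to 120000 nM.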

Compound 4, half-maximal effective concentration: > 25000 nM
Compound 4 was reported as a limit; the forecaster's own chance of this, stated with the estimate: 85%; the middle value is on the limit's open side.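

No new step can be read from compound 3 to compound 4, since both stand at a limit of the assay and not at a number: the limit of > 25000 nM in this assay, at which 4 of the 4 values shown sit.

The compounds shown leave open how much of each is needed for the effect in this assay and whether fluoro in place of methyl changes that amount at all.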